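The source may hold more compounds than are shown below. What is called first, only, known or untested is meant among the compounds shown, and "the series" means these compounds.

Measured compounds:
compound 1, `CCSc1nc2c(cc(-c3ccc(Cl)cc3)n2-c2ccccc2)c(=N)s1`, 1%
compound 2, `CCC(C)Sc1nc2c(cc(-c3ccccc3)n2-c2ccccc2)c(=N)s1`, 50%

Of the compounds shown here, two have been measured in a functional assay on the whole organism for inhibition, with Rattus norvegicus as the target, read by ELISA, with stated times of 30 min and 6 h, at a dose of 30 mg/kg by the oral route; on this read-out lower numbers stand for less inhibition and higher numbers for more inhibition at the one dose given (going by the name of the read-out). Compound 2 gives 50% and stands highest of the two numbers; its nearest neighbour is compound 1, which gives 1%, a gap that lies beyond the scatter. Among the compounds with values here, compound 1 and compound 2 differ in more than one place, so no single step between them is counted, and only their two values are known.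

The next compound is compound 3, `CCC(C)Sc1nc2c(cc(-c3ccc(Cl)cc3)n2-c2ccccc2)c(=N)s1`. It differs from compound 2 by chloro in place of hydrogen on an aromatic carbon. The chloro enters on an aromatic carbon of a six-membered aromatic ring of carbon only, para to a large group; the same difference read one bond further out is phenyl to 4-chlorophenyl.

Within the data shown here, no counted step exists for this change. Compound 1, which also carries the chloro, gives a low value, but it differs from compound 2 elsewhere too, so the effect of the chloro alone is not shown. A downward step from compound 2 to compound 3 is expected, of the size a number 20 percentage points lower from compound 2 to compound 3 (beyond the scatter), with wide uncertainty. Compound 3 is estimated at 30%, in the range 5% to 60%.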

Compound 3, a percentage reported as inhibition, in the whole organism at one dose (the size of the read-out at that dose, not a potency): 2%
Estimate against measurement, compound 3: 28 percentage points above; the whole stated range lies above it.
By their numbers in this assay, from the lowest: compounds 1 and 3 (each within the scatter of the next); then compound 2.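

In this assay the chloro on this aromatic carbon, para to a large group, now has a reading of its own: going from phenyl to 4-chlorophenyl gives a number 48 percentage points lower from compound 2 to compound 3 (beyond the scatter) at this one dose. Within the data shown here, with the chloro present, ethyl in place of hydrogen on the saturated chain carbon gives a number 1 percentage points higher from compound 1 to compound 3 (within the scatter) in the same read-out, so this chain change cannot be told apart from no step among the chloro compounds. No measurement at hand bears on why the chloro step is so large.

As far as these compounds go, what a fluoro, a methoxy or an amine would give on the same aromatic carbon stays open. So does how the chain change reads when that aromatic carbon carries hydrogen, and what a longer chain would give on the sulfur.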